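The compounds below may be only part of what the source reports. "The series", "measured", "known", "first", "only" and "open" are said of these compounds alone.

Working notes on the series. Compound 1, `CC[C@H](C)[C@H](NC(=O)CN(c1ncnc2c1ncn2C1CCCCO1)C1CC1)C(=O)OCc1ccccc1`, stands lowest of the two measured compounds in a functional assay on the whole organism (Tail, strain ICR) with Mus musculus as the target, in the tail flick test, with a stated time of 120 min, at a dose of 25 umol/kg by the oral route; on this read-out lower numbers stand for a weaker effect and higher numbers for a stronger effect at the one dose given: compound 1 gives 20.4%. Compound 2, `C[C@@H](O)[C@H](NC(=O)CN(c1nc(Cl)nc2[nH]cnc12)C1CC1)C(=O)O`, in this assay gives 37.6%, a number beyond the scatter above that of compound 1; the two compounds differ in several places, so only the two values themselves can be compared.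

The step now followed goes from compound 1 to compound 3, `CC(C)[C@H](NC(=O)CN(c1ncnc2c1ncn2C1CCCCO1)C1CC1)C(=O)OCc1ccccc1`. The change is hydrogen in place of methyl on a saturated chain carbon, three bonds along the chain from an amide-type nitrogen and a carbonyl carbon. The same difference, cut one bond further out, reads sec-butyl to isopropyl. For the measured compounds named here, no measured pair shows this change on its own, so there is no step to lean on.

A small step is expected here, within the scatter, with no clear direction. For compound 3 in this assay the expected value is 20%, with a range from 8% to 34%, which means an expected step of a number 0.4 percentage points lower from compound 1 to compound 3 (within the scatter).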

Compound 3, a percentage reported as activity, at one dose (the size of the read-out at that dose, not a potency): 25.8%
The estimate for compound 3 lay 5.8 percentage points below the measured number; the measured number falls inside the stated range.
By their numbers in this assay, from the lowest: compounds 1 and 3 (each within the scatter of the next); then compound 2.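

In this assay, hydrogen in place of methyl on a saturated chain carbon, three bonds along the chain from an amide-type nitrogen and a carbonyl carbon, gives a step of a number 5.4 percentage points higher from compound 1 to compound 3 (within the scatter). For the compounds shown here, this is the first comparison that isolates a single change, and on this read-out, at the one dose given, sec-butyl and isopropyl at this place cannot be told apart. No measured evidence bears on this result.

What a longer chain such as n-hexyl, or an amine, would give at this place remains open, since the two groups shown span only a single-carbon difference. From the compounds shown here alone, whether the same change would read alike on the core of compound 2 also remains open.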